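This account rests on a few compounds, and the source may have more. Where it says the series, first, only, none or still open, it means among the compounds named here.

Compound 3 `c1coc(-c2ccccc2OCC2=NCCN2)c1` is one of the two compounds with a read number in a functional assay for activation of Alpha-1A adrenergic receptor (Homo sapiens), read by calcium flux (a lower number here means that less compound is needed, a higher number that more compound is needed for the effect), where compound 3 gives 1.26 nM. The other, compound 1 `c1cncc(-c2ccccc2OCC2=NCCN2)c1`, gives 2 nM in this assay, and the step of a 1.6-fold lower number from compound 1 to compound 3 (0.20 log units; within the scatter) lies within the scatter. Compound 2 `c1ccc(-c2ccncc2)c(OCC2=NCCN2)c1` gives only a limit in this assay, < 100000 nM. The steps a step that the limit leaves unreadable from compound 1 to compound 2 and a step that the limit leaves unreadable from compound 2 to compound 3 therefore cannot be read. Compound 4 `Cc1ccc(-c2ccccc2OCC2=NCCN2)s1` differs from compound 3 by 5-methylthiophen-2-yl in place of furan-2-yl on an aromatic carbon. Among the measured compounds shown here, the one readable step, a 1.6-fold lower number from compound 1 to compound 3 (0.20 log units; within the scatter), exchanged pyridin-3-yl for furan-2-yl at the same aromatic carbon without moving beyond the scatter; no measured step involves a 5-methylthiophen-2-yl group. The expected step is a 1.2-fold higher number from compound 3 to compound 4 (0.08 log units; within the scatter), within the scatter. Compound 4 is estimated at 1.5 nM, ranging from 0.4 nM to 6 nM.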

Compound 4, half-maximal effective concentration: 25.1 nM
Estimate against measurement, compound 4: 17-fold (1.22 log units) below; measured number above the stated range.
By their numbers in this assay, from the lowest: compounds 3 and 1 (each within the scatter of the next); then compound 4.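

In this assay, 5-methylthiophen-2-yl gives a 20-fold higher number from compound 3 to compound 4 (1.30 log units; beyond the scatter) and a 13-fold higher number from compound 1 to compound 4 (1.10 log units; beyond the scatter), so this aromatic carbon does not accept every five-membered aromatic ring equally, although pyridin-3-yl and furan-2-yl lay within the scatter of each other. The step between compound 2 and compound 4 cannot be read, as compound 2 has only a limit. Nothing given here explains the size of these steps.

This change swaps oxygen for sulfur and adds a methyl group at once, and the compounds shown do not separate the two. Plain thiophen-2-yl or 5-methylfuran-2-yl would be the single changes that could tell them apart.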